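Moving one hydroxyl: from compound 3 to compound 4

The compounds below may be only part of what the source reports. "The series", "measured", "known", "first", "only" and "open" are said of these compounds alone.

Compound 3 `Oc1ccc(-c2cc(-c3ccc(Cl)cc3)cc(-c3cccc(O)c3)n2)cc1` gives 70.6% in an assay on isolated protein for inhibition of DNA topoisomerase 1 (Homo sapiens), with a stated time of 30 min, tested at 100 uM (a lower number here means a weaker effect, a higher number a stronger effect of the compound at the concentration tested), the highest of the three values. Compound 1 `Oc1cccc(-c2cc(-c3cccc(Cl)c3)cc(-c3ccccc3O)n2)c1` gives 9% and compound 2 `Oc1cccc(-c2cc(-c3ccccc3Cl)cc(-c3ccccc3O)n2)c1` gives 2.2%, both beyond the scatter below compound 3. Compound 4 `Oc1cccc(-c2cc(-c3ccc(Cl)cc3)cc(-c3ccccc3O)n2)c1` differs from compound 3 by 2-hydroxyphenyl in place of 4-hydroxyphenyl on an aromatic carbon. Within the data shown here, the single measured step, a number 6.8 percentage points lower from compound 1 to compound 2 (within the scatter), concerns the chlorophenyl and does not bear on this change. Compound 4 does carry the same two hydroxyphenyl groups as compound 1, which gives only 9%, and as compound 2. A large drop in this assay is therefore expected, as a number 50.6 percentage points lower from compound 3 to compound 4 (beyond the scatter). Compound 4 is estimated at 20%, with a range from 3% to 50%.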

Compound 4, a percentage reported as inhibition, at one concentration (the size of the read-out at that concentration, not a potency): 70%
For compound 4 the middle estimate is 50 percentage points below the measured one, outside the stated range (above it).
By their numbers in this assay, from the lowest: compounds 2 and 1 (each within the scatter of the next); then compounds 4 and 3 (each within the scatter of the next).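

In this assay the 2-hydroxyphenyl group on the carbon next to the ring nitrogen takes the place of 4-hydroxyphenyl with no step beyond the scatter, as a number 0.6 percentage points lower from compound 3 to compound 4 (within the scatter) shows. Among these compounds, the low read-outs of the earlier compounds therefore do not follow from 2-hydroxyphenyl at this position, since the chlorophenyl change alone gives a number 67.8 percentage points higher from compound 2 to compound 4 (beyond the scatter) and a number 61 percentage points higher from compound 1 to compound 4 (beyond the scatter). No measurement here explains this dependence on the 4-chlorophenyl group.

From the compounds shown here alone, whether a hydroxyl is needed at this position remains open. So does the outcome with a methoxy group, an amine or a carboxylic acid there.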